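The compounds below may be only part of what the source reports. "The series", "measured", "known", "first", "only" and "open" are said of these compounds alone.

Measured in a physicochemical assay for solubility, read by HPLC, in phosphate buffer, at pH 6.5; on this read-out lower numbers stand for lower solubility and higher numbers for higher solubility:

Compound 1 `COC(=O)C1=C(C)NC(c2nccs2)=NC1(C)c1ccc(S(C)(=O)=O)cc1` gives 365 ug/mL.
Compound 2 `COC(=O)C1=C(C)NC(c2nccs2)=NC1(C)c1ccc(F)c(F)c1` gives 50 ug/mL.
Compound 3 `COC(=O)C1=C(CN2CCNC(=O)C2)NC(c2nccs2)=NC1(C)c1ccc(F)cc1` gives 34 ug/mL.

Compound 3 stands lowest of the three numbers in this assay. Its nearest neighbour is compound 2, whose number is within the scatter of that of compound 3, so no order between those two can be read. Compound 1 stands well apart, its number beyond the scatter above that of compound 3.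

Compound 4 `COC(=O)C1=C(COCC(F)(F)F)NC(c2nccs2)=NC1(C)c1ccc(F)cc1` is not yet measured in this assay. It differs from compound 3 in one place: 2,2,2-trifluoroethoxy in place of 3-oxopiperazin-1-yl on a saturated chain carbon bound to a double-bonded ring carbon. Among the compounds with values here, no measured pair shows this change, so its size rests on expectation alone. Given that compound 3 already sits at 34 ug/mL at the low end of the series, the step of a 2.8-fold lower number from compound 3 to compound 4 (0.45 log units; beyond the scatter) is expected to run downward, by an amount somewhat beyond the scatter. Compound 4 is therefore estimated at 12 ug/mL, with a range from 4 ug/mL to 35 ug/mL.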

Compound 4, solubility: 19 ug/mL
Compound 4: the middle estimate sits 1.6-fold (0.20 log units) below what was measured; the range from low to high includes it.
By their numbers in this assay, from the lowest: compounds 4, 3 and 2 (each within the scatter of the next, the first and the last beyond it); then compound 1.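

In this assay, 2,2,2-trifluoroethoxy in place of 3-oxopiperazin-1-yl on a saturated chain carbon bound to a double-bonded ring carbon gives a 1.8-fold lower number from compound 3 to compound 4 (0.25 log units; within the scatter), so no order between the two compounds can be read. Within the data shown here, this is the first pair that differs in one place, and it shows that losing the ring and the hydrogen-bond donor of 3-oxopiperazin-1-yl brings no step beyond the scatter here, in this single pair. Nothing measured on these compounds offers an explanation for this result.

On these data alone, whether an amine or a carboxylic acid on that saturated chain carbon would give a step beyond the scatter remains open. Also open, as far as these compounds go, is whether the same exchange would read alike with the methylsulfonyl group of compound 1 in place of the fluorine of compound 3.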